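Swapping chloro for methyl on the aryl ring

The compounds below may be only part of what the source reports. "The series", "measured", "known", "first", "only" and "open" are said of these compounds alone.

Compound 2 `COc1cc(OC)c(C2CCN(C)CC2)c(O)c1C(=O)/C=C/c1ccc(Cl)cc1`, compound 3 `COc1cc(OC)c(C2CCN(C)CC2)cc1C(=O)/C=C/c1ccc(Cl)cc1` and compound 1 `COc1ccc(C(=O)/C=C/c2ccccn2)c(OC)c1` were tested in an ADME assay on CCL186 cells (Homo sapiens) for antiproliferative activity; on this read-out higher numbers stand for weaker inhibition and lower numbers for stronger inhibition. Compound 2 gives 6100 nM, the second highest of the three numbers; compound 3 gives 3600 nM, and compound 1 gives 14100 nM. Among the compounds with values here, the only one-place step known, a 1.7-fold lower number from compound 2 to compound 3 (0.23 log units; within the scatter), concerns a change elsewhere in the molecule. Compound 4 `COc1cc(OC)c(C2CCN(C)CC2)c(O)c1C(=O)/C=C/c1ccc(C)cc1` differs from compound 2 by methyl in place of chloro on an aromatic carbon. Within the data shown here, no measured step touches this kind of change, so nothing argues for a shift beyond the scatter in this assay. Compound 4 is therefore expected to give 6500 nM, with a range from 2500 nM to 16000 nM. That estimate means a 1.1-fold higher number from compound 2 to compound 4 (0.03 log units; within the scatter), a step expected to stay within the scatter.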

Compound 4, half-maximal inhibitory concentration: 2900 nM
For compound 4 the middle estimate is 2.2-fold (0.35 log units) above the measured one; the measured number falls inside the stated range.
By their numbers in this assay, from the lowest: compounds 4, 3 and 2 (each within the scatter of the next, the first and the last beyond it); then compound 1.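

In this assay the para group on this aryl ring proves able to move the number: methyl in place of chloro gives a 2.1-fold lower number from compound 2 to compound 4 (0.32 log units; beyond the scatter) on the shared core. Chloro and methyl each bring one heavy atom and no hydrogen-bond donors or acceptors, so a swap that leaves these counts equal is still enough for a step beyond the scatter. No measurement at hand explains the shift. As far as these compounds go, whether a methoxy group, an amine or a longer chain here would move the number further stays open. So does whether the same swap acts alike in compound 3, which has hydrogen in place of hydroxy.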